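A few compounds are considered here, and "the series" means these few. Any claim that something is new, unique, unknown or untested is made for them only; others in the source may bear on it.

Measured compounds:
Compound 1, `O=S(=O)(NCCNc1nccc(-c2c(-c3cccc(F)c3)nc3sccn23)n1)c1ccc(Br)cc1`: 13500 nM
Compound 2, `O=S(=O)(NCCNc1nccc(-c2c(-c3cccc(F)c3)nc3sccn23)n1)c1cccc(F)c1`: 18300 nM

Of the compounds shown here, two have been tested in a functional assay on SK-MEL-28 cells (Homo sapiens) for cytotoxicity, read by MTT assay; a lower number here means a stronger inhibitor, a higher number a weaker inhibitor. Compound 1 gives 13500 nM, and compound 2 gives 18300 nM; the two values lie within the scatter of each other, so neither can be called the stronger or weaker of the pair. For the measured compounds named here, the one step between them, a 1.4-fold higher number from compound 1 to compound 2 (0.13 log units; within the scatter), concerns only the aryl group on the sulfonyl sulfur.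

Compound 3, `O=S(=O)(NCCCNc1nccc(-c2c(-c3cccc(F)c3)nc3sccn23)n1)c1ccccc1`, has not yet been measured in this assay. It differs from compound 2 by ((phenylsulfonyl)amino)methyl in place of ((3-fluorophenyl)sulfonyl)amino on a saturated chain carbon, two bonds along the chain from a nitrogen on an aromatic ring. The change thus touches two things at once: the fluorine on the sulfonyl aryl is gone, and the saturated chain between the sulfonamide nitrogen and the ring nitrogen is one carbon longer. Going by the values given here, only the first of these has a precedent here, the step from compound 1 to compound 2, which stayed within the scatter; for the longer chain there is no measured step at all. On that basis no step beyond the scatter is expected from compound 2 to compound 3 in this assay, the expected step being a 1.1-fold lower number from compound 2 to compound 3 (0.06 log units; within the scatter), but the range must be wide. Compound 3 is therefore estimated at 16000 nM, with a range from 6000 nM to 45000 nM.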

Compound 3, half-maximal inhibitory concentration: 6850 nM
Estimate against measurement, compound 3: 2.3-fold (0.37 log units) above, and the stated range covers the measured number.
By their numbers in this assay, from the lowest: compounds 3, 1 and 2 (each within the scatter of the next, the first and the last beyond it).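

In this assay, for the compounds shown here, the change at this position gives the first step beyond the scatter (a 2.7-fold lower number from compound 2 to compound 3 (0.43 log units; beyond the scatter)), whereas the change of aryl group from compound 1 to compound 2 had separated nothing. Yet when ((phenylsulfonyl)amino)methyl replaces ((4-bromophenyl)sulfonyl)amino on the same saturated chain carbon, the result stays within the scatter (a 2.0-fold lower number from compound 1 to compound 3 (0.29 log units; within the scatter)), so the modest separation holds against compound 2 alone and compound 3 cannot be set apart from compound 1. No available evidence accounts for the step, and the values do not divide it between the loss of the fluorine and the longer chain.

The compounds shown leave open whether the step follows the extra chain carbon or the unsubstituted phenyl, a question that the phenylsulfonyl group on the shorter chain or the 3-fluorophenylsulfonyl group on the longer chain would address. Also open, going by these compounds, is how a still longer chain, or a carboxamide in place of the sulfonamide, would read in this assay at this position.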